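Swapping a Benzyl Group for Isopropyl on a Salicylanilide

The source may report more compounds than this note shows. Statements on the series, on what has been measured and on what is new or still open speak of the compounds shown alone.

Measured compounds:
- compound 1, `CC(=O)Nc1ccc(NC(=O)c2cc(Cl)ccc2O)c(Cl)c1`, an ADME assay on A549 cells (Homo sapiens) for cytotoxicity, read by LDH release, with a stated time of 15 h; a higher number here means that more compound is tolerated, a lower number that less compound is tolerated: "not determined" (no result reported)
- compound 2, `O=C(Nc1ccc(NCc2ccco2)cc1Cl)c1cc(Cl)ccc1O`, this assay: 76300 nM
- compound 3, `O=C(Nc1ccc(NCc2ccc(F)cc2)cc1Cl)c1cc(Cl)ccc1O`, this assay: "not determined" (no result reported)

Three compounds share one core, and only compound 2 carries a number in this assay, where compound 2 gives 76300 nM. Compound 3 stands without a single number in this assay, and compound 1 is a further entry without a single number, so nothing measured fixes where compound 3 itself sits.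

The step to compound 4, `CC(C)Nc1ccc(NC(=O)c2cc(Cl)ccc2O)c(Cl)c1`, is small: isopropyl in place of 4-fluorobenzyl on a nitrogen on an aromatic ring. Going by the values given here, no measured pair shows what such a change does to tolerance in this assay, so the expectation rests on the one number available, that of compound 2, and on the modest size of the change. A shift beyond the usual scatter in either direction is not expected.

For compound 4 the value in this assay is estimated at 70000 nM, with a range from 20000 nM to 200000 nM.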

Compound 4, half-maximal cytotoxic concentration: 82700 nM
For compound 4 the middle estimate is 1.2-fold (0.07 log units) below the measured one; the range from low to high includes it.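

Until now a single number stood at this position, so nothing showed how this assay responds when the group on a nitrogen on an aromatic ring is exchanged. Isopropyl in place of (furan-2-yl)methyl gives a 1.1-fold higher number from compound 2 to compound 4 (0.03 log units; within the scatter) and lies within the scatter, so for this pair, a group with a ring and a group with no ring cannot be told apart in tolerance. No supporting data explain this result.

On these data alone, compound 3 has no single number, so the step from 4-fluorobenzyl to isopropyl itself cannot be read, and whether a 4-fluorobenzyl group behaves like the (furan-2-yl)methyl group stays open. The compounds shown also leave open whether a carboxylic acid or a longer chain on that nitrogen would leave tolerance just as undisturbed.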